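The source may report more compounds than this note shows. Statements on the series, on what has been measured and on what is new or still open speak of the compounds shown alone.

Two members of the series have numbers in a functional assay on the whole organism (artery, strain albino) with Rattus norvegicus as the target, with a stated time of 360 min, at a dose of 10 mg/kg by the oral route (on this read-out lower numbers stand for less inhibition and higher numbers for more inhibition at the one dose given (going by the name of the read-out)), so far. Compound 1 `COc1ccc(C2N=C(SCc3ccc(Cl)cc3)NC(C)=C2C(=O)Nc2ccc(Br)cc2)cc1` gives 39.2% in this assay. Compound 2 `CC1=C(C(=O)Nc2ccc([N+](=O)[O-])cc2)C(c2ccc(Br)cc2)N=C(SCc2ccccc2)N1` gives 37.6% in this assay, the lowest of the two numbers shown; the gap to compound 1 is within the scatter, so the two read as alike, and no ordering between them is claimed.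

Compound 3 `CC1=C(C(=O)Nc2ccc([N+](=O)[O-])cc2)C(c2ccc(Br)cc2)N=C(SCc2ccccc2Cl)N1` has not yet been measured. The change from compound 2 to compound 3 is chloro in place of hydrogen on an aromatic carbon, on an aromatic carbon of a six-membered aromatic ring of carbon only. Among the measured compounds shown here, no measured pair carries a step of this kind, so its size is unknown here.

The step from compound 2 to compound 3 is expected to be small, a number 2.4 percentage points higher from compound 2 to compound 3 (within the scatter), not clearly beyond the scatter in either direction. On that basis compound 3 is estimated at 40% in this assay, within a range of 25% to 55%.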

Compound 3, a percentage reported as inhibition, in the whole organism at one dose (the size of the read-out at that dose, not a potency): 13.9%
The estimate for compound 3 lay 26.1 percentage points above the measured number; the measured number lies below the stated range.
By their numbers in this assay, from the lowest: compound 3; then compounds 2 and 1 (each within the scatter of the next).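

The benzylsulfanyl group is sensitive to substitution: going to (2-chlorobenzyl)sulfanyl, with chloro in place of hydrogen ortho to a large group, gives a number 23.7 percentage points lower from compound 2 to compound 3 (beyond the scatter) in this assay. A single added chlorine atom on this aromatic ring is therefore enough to move the inhibition at the one dose given beyond the scatter, and downward, something compound 1 and compound 2, which differ in more than one place, could not show. Nothing at hand speaks to what lies behind this drop.

Among the compounds shown here, whether the drop belongs to chloro itself or to this place on the ring remains open, as this is the only single-place step. A methyl group or an amine on the same carbon would help separate the two readings.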